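Removing One Benzyl Group from Compound 2

The compounds below may be only part of what the source reports. "The series", "measured", "known", "first", "only" and "open" are said of these compounds alone.

The study follows cytotoxicity in a functional assay on HCT-8 cells (Homo sapiens) for cytotoxicity, read by MTT assay, with a stated time of 72 h; a lower number here means a stronger inhibitor, a higher number a weaker inhibitor. Compound 1 `C=CC(C)(C/C=C(\C)CCC=C(C)C)c1ccc(O)c(O)c1` gives 12.2 ug/mL in this assay. Compound 2 `C=CC(C)(C/C=C(\C)CCC=C(C)C)c1ccc(OCc2ccccc2)c(OCc2ccccc2)c1` was reported in this assay as "not active" (no number reported), so no single number stands behind compound 2, and it can only be set against compound 1 by noting that compound 1 returned a numerical concentration and compound 2 did not. The step under consideration trims one benzyl. Compound 3 `C=CC(C)(C/C=C(\C)CCC=C(C)C)c1ccc(OCc2ccccc2)c(O)c1` differs from compound 2 in this way: hydrogen in place of benzyl on an oxygen on an aromatic ring. For the measured compounds named here, no measured pair of compounds covers this change, so the size of the step cannot be read off from data. Because compound 1 gave 12.2 ug/mL while compound 2 gave no number, compound 3 is expected to move in the direction of a stronger inhibitor than compound 2 and to return a measurable concentration, though probably as a weaker inhibitor than compound 1. Compound 3 is estimated at 25 ug/mL, with a range from 8 ug/mL to 80 ug/mL in this assay.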

Compound 3, half-maximal inhibitory concentration: "not active" (no number reported)
Nothing numeric was reported for compound 3, so the estimate cannot be set against anything.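

In this assay, for the compounds shown here, compound 3 gives "not active" (no number reported) and compound 2 gives "not active" (no number reported) in the same way, so no step between compound 2 and compound 3 can be read. The compounds shown leave open what removing one benzyl alone does to cytotoxicity, since only compound 1 returned a number. No evidence bears on this result.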